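This account rests on a few compounds, and the source may have more. Where it says the series, first, only, none or still open, it means among the compounds named here.

Of the compounds shown here, three that share one core have been tested in a functional assay on HOS-TE85 cells (Homo sapiens) for inhibition, read by CCK-8 assay, with a stated time of 72 h, tested at 1 uM; a higher number here means more inhibition at the concentration tested (going by the name of the read-out), a lower number less inhibition. Compound 1 `COc1ccc(C)cc1N1C(=O)CSC1c1cccc(C(=O)NCCCCc2ccccc2)c1` gives 95%. Compound 2 `COc1ccc(OC)c(N2C(=O)CSC2c2cccc(C(=O)NCCCCc3ccccc3)c2)c1` gives 20%, and compound 3 `CCN1C(=O)CSC1c1cccc(C(=O)NCCCCc2ccccc2)c1` gives 0%. Of these three numbers compound 2 stands second highest: compound 3 is its nearest neighbour, and compound 1 lies furthest from it. The measured steps show how much the group on the ring nitrogen matters. Swapping methoxy in place of methyl on an aromatic carbon gave a number 75 percentage points lower from compound 1 to compound 2 (beyond the scatter). Replacing the whole aryl group by a small alkyl gave a number 20 percentage points lower from compound 2 to compound 3 (beyond the scatter) and, from the compound with the highest number, a number 95 percentage points lower from compound 1 to compound 3 (beyond the scatter).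

Compound 4 `COc1cc(F)ccc1N1C(=O)CSC1c1cccc(C(=O)NCCCCc2ccccc2)c1` differs from compound 2 in one place: 4-fluoro-2-methoxyphenyl in place of 2,5-dimethoxyphenyl on an amide-type nitrogen in a ring. One methoxy group is thus removed and a fluorine is introduced, while the other methoxy stays. The step from compound 1 to compound 2 bears most directly on this, as it shows that one small change on this aryl group can move the read-out a long way, and the step from compound 2 to compound 3 shows the aryl group itself carries the activity. Going by the values given here, no measured compound carries a fluorine, so the direction is uncertain, though the loss of a methoxy points upward. Compound 4 is therefore estimated to give 55%, expected to lie between 15% and 90%. This would mean an expected step of a number 35 percentage points higher from compound 2 to compound 4 (beyond the scatter).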

Compound 4, a percentage reported as inhibition, at one concentration (the size of the read-out at that concentration, not a potency): 94%
Compound 4: middle estimate off by 39 percentage points, on the low side; the whole stated range lies below it.
By their numbers in this assay, from the lowest: compound 3; then compound 2; then compounds 4 and 1 (each within the scatter of the next).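

In this assay, the exchange of 2,5-dimethoxyphenyl for 4-fluoro-2-methoxyphenyl on the amide-type nitrogen gave a number 74 percentage points higher from compound 2 to compound 4 (beyond the scatter) and so showed that a methoxy-bearing aryl group at this place can restore a high reading, leaving compound 2 as the low case among the three aryl compounds. The comparison with the 2-methoxy-5-methylphenyl compound gave a number 1 percentage points lower from compound 1 to compound 4 (within the scatter) and thus adds something new: two different aryl groups at this place, one with a fluorine and one with a methyl, cannot be told apart in this read-out. The step of a number 94 percentage points higher from compound 3 to compound 4 (beyond the scatter) from the ethyl compound gives a second aryl example, alongside compound 1, of a far higher reading than ethyl gives, while compound 2 shows that an aryl group alone does not ensure this.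

Still open, as far as these compounds go, is whether the shared methoxy contributes at all, and how a plain phenyl, or a chlorine, an amine or a carboxylic acid on this aryl group, would read. Nothing at hand accounts for why the fluorine and methyl compounds read so differently from the dimethoxy compound.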